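Taking the 4-cyanobenzyl group off compound 3

The source may hold more compounds than are shown below. What is called first, only, known or untested is meant among the compounds shown, and "the series" means these compounds.

In an ADME assay on CHO cells (Cricetulus griseus) for inhibition, read by MTT assay (on this read-out higher numbers stand for weaker inhibition and lower numbers for stronger inhibition), compound 1 `CC(C)(C)NCc1cc(Cl)cc(Nc2nc3ccccc3n2Cc2ccc(C(F)(F)F)cc2)c1O` gives 36300 nM. Compound 2 `CCN(CC)Cc1cccc(Nc2nc3ccccc3n2Cc2ccc(C#N)cc2)c1O` reaches only a limit of the assay, > 50000 nM. Among the measured compounds shown here, compound 3 `CCN(CC)Cc1cc(C)cc(Nc2nc3ccccc3n2Cc2ccc(C#N)cc2)c1O` gives 14200 nM, the lowest number so far. For the measured compounds named here, the only measured step, an at least 3.5-fold lower number from compound 2 to compound 3 (0.54 log units; beyond the scatter), came with methyl in place of hydrogen on an aromatic carbon. That is a different change, so it bears only loosely on what follows. Compound 4 `CCN(CC)Cc1cc(C)cc(Nc2nc3ccccc3[nH]2)c1O` has hydrogen in place of 4-cyanobenzyl on an aromatic nitrogen. Going by the values given here, no measured step removes this group, so the forecast is cautious. The expected change is a 1.8-fold higher number from compound 3 to compound 4 (0.25 log units; within the scatter), a modest rise from the lowest number and only an estimate. Compound 4 is expected near 25000 nM, with an estimated range of 10000 nM to 50000 nM.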

Compound 4, half-maximal inhibitory concentration: > 50000 nM
Compound 4 ended at the assay's limit; the forecaster's own chance of this, stated with the estimate: 30%; at least 2.0-fold (0.30 log units) between middle value and limit.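

Putting hydrogen in place of 4-cyanobenzyl on the aromatic nitrogen gives an at least 3.5-fold higher number from compound 3 to compound 4 (0.54 log units; beyond the scatter) in this assay. Among the compounds shown here, this is the first look at this position, and within this pair a measurable number goes with the 4-cyanobenzyl group being present. The full size of the rise stays unknown, because compound 4 sits at a limit and not at a true number: the limit of > 50000 nM in this assay, at which 2 of the 4 values shown sit.

The compounds shown leave open whether the benzyl ring alone or its nitrile goes with the lower number. A plain benzyl group or a short ethyl chain on this nitrogen would be untested ground.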